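The source may report more compounds than this note shows. Statements on the series, on what has been measured and on what is new or still open speak of the compounds shown alone.

The measured compounds, all read in a functional assay on HeLa cells (Homo sapiens) for antiproliferative activity, read by MTT assay, with a stated time of 72 h; a lower number here means a stronger inhibitor, a higher number a weaker inhibitor:

Compound 1, `COc1cc(CC(O)(COCc2ccccc2)COCc2ccccc2)nc(OC)n1` — in this assay compound 1 gives only the limit > 100000 nM.
Compound 2, `O=c1cc(CC(O)COCc2ccccc2)[nH]c(=O)[nH]1` — in this assay compound 2 gives only the limit > 100000 nM.
Compound 3, `Cc1c(CC(O)COCc2ccccc2)[nH]c(=O)[nH]c1=O` — in this assay compound 3 gives only the limit > 100000 nM.

Compound 3 therefore stands at a limit, not a number, and all three values sit at that same limit (the limit of > 100000 nM in this assay, at which 3 of the 3 values shown sit). Among the compounds with values here, the one step that touches it, a step that the two limits leave unreadable from compound 2 to compound 3, cannot be read. Compound 4, `COCn1c(CC(O)COCc2ccccc2)c(C)c(=O)[nH]c1=O`, differs from compound 3 by methoxymethyl in place of hydrogen on an aromatic nitrogen. Within the data shown here, no measured step gives a readable size, so nothing points to a change beyond the scatter. Compound 4 is expected to remain at the limit, an estimated 150000 nM (range 50000 nM to 500000 nM), the expected step being a step that the limit leaves unreadable from compound 3 to compound 4.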

Compound 4, half-maximal inhibitory concentration: > 100000 nM
Compound 4 ended at the assay's limit; the forecaster's own chance of this, stated with the estimate: 85%; the middle value does not contradict the limit.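

No size can be read for the step between compound 3 and compound 4, as both values are limits: the limit of > 100000 nM in this assay, at which 4 of the 4 values shown sit.

The compounds shown leave open which change to the shared core, if any, would give a readable value in this assay.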